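Bulky carbocycles on the aminopyrimidine side chain

The source may hold more compounds than are shown below. What is called first, only, known or untested is meant among the compounds shown, and "the series" means these compounds.

Measured so far in a functional assay (aorta) with Oryctolagus cuniculus as the target; on this read-out higher numbers stand for weaker inhibition and lower numbers for stronger inhibition:
- compound 1 `Nc1ccnc(-c2nn(Cc3ccccc3F)c3ncccc23)n1`: 270 nM; 265000 nM (2 entries)
- compound 2 `CCCc1cnc(-c2nn(Cc3ccccc3F)c3ncccc23)nc1N`: 252000 nM
- compound 3 `Nc1nc(-c2nn(Cc3ccccc3F)c3ncccc23)ncc1C1CCC1`: 633000 nM

Compound 1 carries two entries far apart, (the several entries of compound 1 in this assay, 270 nM; 265000 nM (2 entries)), so it gives no single number to rank against. Among the single numbers, compound 3 stands highest; its nearest neighbour is compound 2, and the step of a 2.5-fold higher number from compound 2 to compound 3 (0.40 log units; beyond the scatter) is the only measured step in the set.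

Compound 4 `Nc1nc(-c2nn(Cc3ccccc3F)c3ncccc23)ncc1C1CCCCC1` differs from compound 3 by cyclohexyl in place of cyclobutyl on an aromatic carbon. Among the measured compounds shown here, the only step that bears on it is a 2.5-fold higher number from compound 2 to compound 3 (0.40 log units; beyond the scatter), where enlarging the carbon group at this position raised the number by a modest margin. For the measured compounds named here, on that basis a further modest rise in this assay is expected for compound 4, in the same direction, though the single precedent leaves it open whether the step will clear the scatter. The expected step is a 1.6-fold higher number from compound 3 to compound 4 (0.20 log units; within the scatter). Compound 4 is estimated at 1000000 nM, with a range from 300000 nM to 3500000 nM.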

Compound 4, half-maximal inhibitory concentration: 561000 nM
Compound 4: middle estimate off by 1.8-fold (0.25 log units), on the high side; the range from low to high includes it.
By their numbers in this assay, from the lowest: compound 2; then compounds 4 and 3 (each within the scatter of the next).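

In this assay, cyclohexyl in place of cyclobutyl on this aromatic carbon gives a 1.1-fold lower number from compound 3 to compound 4 (0.05 log units; within the scatter), so the larger ring separates neither compound from the other. Cyclohexyl in place of propyl gives a 2.2-fold higher number from compound 2 to compound 4 (0.35 log units; beyond the scatter), in the same direction as a 2.5-fold higher number from compound 2 to compound 3 (0.40 log units; beyond the scatter). Among these three compounds, both carbocycles therefore carry higher numbers than the propyl chain, while the rise does not continue from the four-membered to the six-membered ring.

As far as these compounds go, whether a cyclohexyl ring bearing an amine or a carboxylic acid would stay in this range remains open, as does the effect of a methyl group at the same position. What any carbon group adds relative to compound 1 cannot be read, as its entries lie far apart: the several entries of compound 1 in this assay, 270 nM; 265000 nM (2 entries)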